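The source may report more compounds than this note shows. Statements on the series, on what has been measured and on what is new or still open speak of the compounds shown alone.

Compound 3 `CC(C)Sc1nnc(-c2c(CNCC3CC3)c3ccccc3n2C)n1-c1ccccc1` gives 5.24 in a physicochemical assay for lipophilicity; on this read-out higher numbers stand for higher lipophilicity and lower numbers for lower lipophilicity. Compound 1 `CC(C)Sc1nnc(-c2c(CN3CCCCC3C)c3ccccc3n2C)n1-c1ccccc1` gives 5.95. Compound 2 `COc1ccc(CNCc2c(-c3nnc(SC(C)C)n3-c3ccccc3)n(C)c3ccc(F)cc23)cc1` gives 6.42.

Compound 3 stands lowest of the three: the step of a number 0.71 log units lower from compound 1 to compound 3 (beyond the scatter) separates it from compound 1, and compound 2 lies further above still. Compound 4 `COc1ccc(CNCc2c(-c3nnc(SC(C)C)n3-c3ccccc3)n(C)c3ccccc23)cc1` differs from compound 3 in one place: 4-methoxyphenyl in place of cyclopropyl on a saturated chain carbon bound to an amine nitrogen. Among the compounds with values here, the one measured step swapped a different amine, so it does not cover this change directly. Compound 2 carries the same (4-methoxybenzyl)amino group as compound 4, on a shared core that also bears a fluorine, and its value sits well above compound 3. A rise in this assay is therefore expected. For compound 4 the expected step is a number 0.96 log units higher from compound 3 to compound 4 (beyond the scatter). Compound 4 is estimated at 6.2, within 5.7 to 6.7.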

Compound 4, partition coefficient: 6.27
Compound 4: the middle estimate sits 0.07 log units below what was measured; low and high end bracket the measured number.
By their numbers in this assay, from the lowest: compound 3; then compound 1; then compounds 4 and 2 (each within the scatter of the next).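

In this assay, 4-methoxyphenyl in place of cyclopropyl gives a number 1.03 log units higher from compound 3 to compound 4 (beyond the scatter), which shows that the group on this saturated chain carbon can shift the number strongly. Hydrogen in place of fluoro gives only a number 0.15 log units lower from compound 2 to compound 4 (within the scatter), so compound 2 and compound 4 read as equal here. With a number 0.32 log units higher from compound 1 to compound 4 (beyond the scatter), the (4-methoxybenzyl)amino group also stands apart from 2-methylpiperidin-1-yl. Still open, as far as these compounds go, is what an unsubstituted phenyl or a carboxylic acid would give on this carbon. No evidence here explains why any of these numbers move.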